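A tert-butyl swap on the amine of compound 3

The source may hold more compounds than are shown below. What is called first, only, known or untested is meant among the compounds shown, and "the series" means these compounds.

In a functional assay on SK-BR-3 cells (Homo sapiens) for antiproliferative activity (a lower number here means a stronger inhibitor, a higher number a weaker inhibitor), compound 1 `CC(=O)Oc1ccc(C(=O)Nc2cc3ccc(OCC4CCCN(C)C4)c(C)c3oc2=O)cc1CC=C(C)C` gives 740 nM and compound 2 `CCN(C)CCCOc1ccc2cc(NC(=O)c3ccc(O)c(CC=C(C)C)c3)c(=O)oc2c1C` gives 730 nM. Compound 3 `CCN(CC)CCCOc1ccc2cc(NC(=O)c3ccc(O)c(CC=C(C)C)c3)c(=O)oc2c1C` stands highest of the three, at 4900 nM. Compound 4 `CC(C)=CCc1cc(C(=O)Nc2cc3ccc(OCCCNC(C)(C)C)c(C)c3oc2=O)ccc1O` has the same atoms as compound 3, joined differently: (tert-butyl)amino in place of diethylamino on a saturated chain carbon, three bonds along the chain from an oxygen on an aromatic ring. (tert-Butyl)amino takes the place of diethylamino, three bonds along the chain from an oxygen on an aromatic ring. Among the compounds with values here, one measured step bears on this amine, a 6.7-fold higher number from compound 2 to compound 3 (0.83 log units; beyond the scatter), and it is modest but beyond the scatter. Within the data shown here, no measured compound carries the new group, so a step of similar or smaller size is expected, leaning towards a lower number. The expected change is a 2.5-fold lower number from compound 3 to compound 4 (0.39 log units; beyond the scatter). For compound 4 the estimated value is 2000 nM, with an expected range of 500 nM to 7000 nM.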

Compound 4, half-maximal inhibitory concentration: 660 nM
Beside the measured number, compound 4's estimate is 3.0-fold (0.48 log units) above it; measured number inside the range.
By their numbers in this assay, from the lowest: compounds 4, 2 and 1 (each within the scatter of the next); then compound 3.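

In this assay, (tert-butyl)amino in place of diethylamino gives a clear step (a 7.4-fold lower number from compound 3 to compound 4 (0.87 log units; beyond the scatter)), so two groups with the same atoms, joined differently, read apart at this position. Against ethyl(methyl)amino the same group gives a step within the scatter (a 1.1-fold lower number from compound 2 to compound 4 (0.04 log units; within the scatter)), which leaves diethylamino as the one amine of these three on the propyl chain with the high number. Nothing measured here explains this difference. The compounds shown leave open how dimethylamino, or a ring amine such as pyrrolidine or morpholine, would read at the end of this chain.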